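A few compounds are considered here, and "the series" means these few. Any claim that something is new, unique, unknown or untested is made for them only; others in the source may bear on it.

In an ADME assay on MT4 cells (Homo sapiens) for cytotoxicity, read by MTT assay, with a stated time of 96 h (on this read-out higher numbers stand for lower toxicity in this test and lower numbers for higher toxicity in this test), compound 1 `NS(=O)(=O)c1ccc(N2N=C(c3ccccc3)CC2c2ccccc2F)cc1` gives 42000 nM. Going by the values given here, the only other measured compound, compound 2 `NS(=O)(=O)c1ccc(N2N=C(c3ccc(OCc4ccccc4)cc3)CC2c2ccc(Cl)cc2)cc1`, gives 70000 nM, so the two numbers lie within the usual scatter of each other. Compound 3 `Cc1cccc(C2CC(c3ccccc3)=NN2c2ccc(S(N)(=O)=O)cc2)c1` keeps the core of compound 1 but has 3-methylphenyl in place of 2-fluorophenyl on a saturated ring carbon. Among the compounds with values here, no measured pair shows this change, so no step beyond the scatter is expected in this assay. The estimated step of a 1.2-fold higher number from compound 1 to compound 3 (0.08 log units; within the scatter) stays within that scatter. Compound 3 is expected to give 50000 nM, within an estimated range from 20000 nM to 110000 nM.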

Compound 3, half-maximal cytotoxic concentration: 37000 nM
The estimate for compound 3 lay 1.4-fold (0.13 log units) above the measured number; the range from low to high includes it.
By their numbers in this assay, from the lowest: compounds 3, 1 and 2 (each within the scatter of the next).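

In this assay, going by these compounds alone, placing 3-methylphenyl where 2-fluorophenyl stood on a saturated ring carbon gives a 1.1-fold lower number from compound 1 to compound 3 (0.06 log units; within the scatter) in the first pair that differs in one place only. At this position, then, these two substituted phenyl groups cannot be told apart in this test. No measurement shown offers a reason for this result. Still open, going by these compounds, is whether a non-aromatic group on this carbon, such as an amine or a carboxylic acid, would move the number beyond the scatter.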